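This account rests on a few compounds, and the source may have more. Where it says the series, first, only, none or still open, it means among the compounds named here.

Measured in a functional assay on SGC-7901 cells (Homo sapiens) for cytotoxicity, read by MTT assay, with a stated time of 48 h; on this read-out lower numbers stand for stronger inhibition and higher numbers for weaker inhibition:
- compound 1, `N#Cc1ccc(Cn2cc(COc3ccc4c(=O)ccoc4c3)nn2)cc1`: compound 1 gives > 100000 nM, which is a limit of the assay and not a number.
- compound 2, `O=c1ccoc2cc(OCc3cn(Cc4cccc(F)c4)nn3)ccc12`: compound 2 gives > 100000 nM, again a limit of the assay.
- compound 3, `Cc1ccccc1Cn1cc(COc2ccc3c(=O)ccoc3c2)nn1`: compound 3 gives > 100000 nM, also a limit of the assay.

Compound 3 thus stands only at a limit, and the other two values shown are limits too (the limit of > 100000 nM in this assay, at which 3 of the 3 values shown sit). Within the data shown here, no compound in the set can be ordered against another.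

The next compound is compound 4, `O=c1ccoc2cc(OCc3cn(Cc4ccccc4Cl)nn3)ccc12`. The change from compound 3 is chloro in place of methyl on an aromatic carbon.

The measured steps that bear on this change are those exchanging one benzyl substituent for another: a step that the two limits leave unreadable from compound 1 to compound 3, a step that the two limits leave unreadable from compound 2 to compound 3 and a step that the two limits leave unreadable from compound 1 to compound 2. Each of them is unreadable, since both ends sit at the limit (the limit of > 100000 nM in this assay, at which 3 of the 3 values shown sit). None gives a size or a direction that could be carried to compound 4. What the data show is that three different benzyl substituents all leave the compounds at the limit in this assay; whether a chloro in place of methyl behaves otherwise cannot be read from them.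

Compound 4 is therefore expected to stay at the limit as well, estimated at 150000 nM with a range from 50000 nM to 500000 nM. The estimated step is a step that the limit leaves unreadable from compound 3 to compound 4, i.e. nothing expected beyond the scatter.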

Compound 4, half-maximal inhibitory concentration: > 100000 nM
Compound 4: a limit, no number (the forecaster's own chance of this, stated with the estimate: 85%); the middle value lies beyond the limit too.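

No new step can be read from compound 4 to compound 1, compound 2 or compound 3, as all of these values are limits and none is a number: the limit of > 100000 nM in this assay, at which 4 of the 4 values shown sit.

The compounds shown leave open whether any benzyl substituent on the shared core gives a measurable value in this assay, and how these four compounds rank against one another.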